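The source may hold more compounds than are shown below. What is called first, only, known or untested is meant among the compounds shown, and "the series" means these compounds.

In a functional assay on PC-3 cells (Homo sapiens) for inhibition, read by MTT assay, with a stated time of 72 h (on this read-out higher numbers stand for weaker inhibition and lower numbers for stronger inhibition), the three measured compounds give mostly limits rather than numbers. Compound 1 `CC(C)=CCC/C(C)=C/COc1ccc(C2CC2C(=O)NNC(=O)c2ccncc2)cc1` reaches only the assay limit of > 100000 nM. Compound 2 `COc1ccc(C2CC2C(=O)NNC(=O)c2ccncc2)cc1` likewise gives only the limit of > 100000 nM. Among the measured compounds shown here, compound 3 `CC(C)=CCC/C(C)=C/COc1ccc(C2CC2C(=O)NNc2nncc3ccccc23)cc1` is the one compound with a real number, 24000 nM, and so stands as the only readable point among the three.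

Of the two measured steps, a step that the two limits leave unreadable from compound 1 to compound 2 cannot be sized because the limit of > 100000 nM in this assay, at which 2 of the 3 values shown sit, holds both of its ends, while an at least 4.1-fold lower number from compound 1 to compound 3 (0.61 log units; beyond the scatter) is at least modest.

Compound 4 `CC(C)=CCOc1ccc(C2CC2C(=O)NNc2nncc3ccccc23)cc1` keeps the core of compound 3 and differs by hydrogen in place of 3-methylbut-2-en-1-yl on a saturated chain carbon bound to a double-bonded chain carbon: the 3-methylbut-2-en-1-yl portion leaves and a hydrogen enters, shortening the chain on the oxygen. For the measured compounds named here, no measured step isolates a change of this kind on a compound with a number, so the direction is open; a step no larger than the scatter, leaning toward a somewhat higher number, is expected as a 1.5-fold higher number from compound 3 to compound 4 (0.16 log units; within the scatter). Compound 4 is therefore estimated at 35000 nM, within 12000 nM to 100000 nM.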

Compound 4, half-maximal inhibitory concentration: 81000 nM
For compound 4 the middle estimate is 2.3-fold (0.36 log units) below the measured one; the measured number falls inside the stated range.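

This step puts the first readable size on a change to the chain on the oxygen: replacing 3,7-dimethylocta-2,6-dien-1-yl with 3-methylbut-2-en-1-yl gives a 3.4-fold higher number from compound 3 to compound 4 (0.53 log units; beyond the scatter). So, in the one pair with two real numbers, the shorter chain goes with weaker inhibition, and nothing shown gives a cause for this step. The earlier change on this oxygen, from compound 1 to compound 2, cannot be read, because both of its ends are limits: the limit of > 100000 nM in this assay, at which 2 of the 4 values shown sit.

Two chains with numbers cannot show whether the trend holds across other lengths, or whether the double bonds matter apart from the length. As far as these compounds go, it also remains open whether a saturated 3,7-dimethyloctyl chain or a benzyl group on this oxygen would give a number closer to that of compound 3 or compound 4.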